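The compounds below may be only part of what the source reports. "The series", "measured", "known", "first", "only" and "open" are said of these compounds alone.

Compound 1 `c1ccc(-c2ccc(-c3ccc(-c4nc5ccccc5[nH]4)cc3)cc2)cc1` gives 41200 nM in a functional assay on A549 cells (Homo sapiens) for inhibition, read by sulforhodamine B assay; on this read-out lower numbers stand for stronger inhibition of growth and higher numbers for weaker inhibition of growth. Compound 2 `Fc1ccc(-c2ccc(-c3ccc(-c4nc5ccccc5[nH]4)cc3)cc2)cc1` differs from compound 1 by fluoro in place of hydrogen on an aromatic carbon; in this assay compound 2 gives 33200 nM, a step of a 1.2-fold lower number from compound 1 to compound 2 (0.09 log units; within the scatter). Compound 3 `Cc1ccc2[nH]c(-c3ccc(-c4ccc(-c5ccccc5)cc4)cc3)nc2c1` differs from compound 1 in the core by methyl in place of hydrogen on an aromatic carbon; in this assay compound 3 gives 3630 nM, a step of an 11-fold lower number from compound 1 to compound 3 (1.05 log units; beyond the scatter), and it stands lowest of the three measured numbers. Compound 4 `Cc1ccc2[nH]c(-c3ccc(-c4ccc(-c5ccc(F)cc5)cc4)cc3)nc2c1` carries the same change relative to compound 3, (fluoro in place of hydrogen on an aromatic carbon), at the same place as the change from compound 1 to compound 2. On the strength of that earlier step, the step from compound 3 to compound 4 is expected to be a 1.2-fold lower number from compound 3 to compound 4 (0.07 log units; within the scatter), within the scatter. Compound 4 is therefore estimated at 3100 nM in this assay, between 1300 nM and 7500 nM.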

Compound 4, concentration for 50% growth inhibition: 6030 nM
The estimate for compound 4 lay 1.9-fold (0.29 log units) below the measured number, within the range that was stated.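

In this assay the fluoro change gives a 1.7-fold higher number from compound 3 to compound 4 (0.22 log units; within the scatter) and so, on the methyl-bearing core as on the core of compound 1, phenyl to 4-fluorophenyl stays within the scatter: the same change on two cores in this assay, a 1.2-fold lower number (0.09 log units; within the scatter) from compound 1 to compound 2 and a 1.7-fold higher number (0.22 log units; within the scatter) from compound 3 to compound 4, 2.1-fold (0.31 log units) apart, within the scatter of two such steps. The methyl change, read on the fluoro-bearing pair, gives a 5.5-fold lower number from compound 2 to compound 4 (0.74 log units; beyond the scatter) and so remains beyond the scatter, at a size not separable from the earlier step: the same change on two cores in this assay, an 11-fold lower number (1.05 log units; beyond the scatter) from compound 1 to compound 3 and a 5.5-fold lower number (0.74 log units; beyond the scatter) from compound 2 to compound 4, 2.1-fold (0.31 log units) apart, within the scatter of two such steps. Both changes therefore carried across in these two pairs, but two pairs set no general rule and do not explain the size of the methyl step.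

As far as these compounds go, whether an amine or a carboxylic acid in place of the fluoro would behave the same remains open. So does whether a longer chain in place of the methyl would keep the methyl step.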